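The compounds below may be only part of what the source reports. "The series", "measured", "known", "first", "only" and "open" are said of these compounds alone.

Compound 1 `CCCCCCN1CCC(N2CC(c3ccnc4ccc(OC)cc34)OC2=O)CC1` and compound 2 `COc1ccc2nccc(C3CN(C4CCN(Cc5ccc(C#N)cc5)CC4)C(=O)O3)c2c1` share a core and differ only in the group on a saturated chain carbon bound to an amine nitrogen in a ring. For the measured compounds named here, in an in vitro functional assay on RBL cells for antagonist activity at C-C chemokine receptor type 8 (Homo sapiens), read by FLIPR and calcium flux (a lower number here means a stronger inhibitor, a higher number a weaker inhibitor), compound 1 gives 501 nM, while compound 2 gives 12600 nM, the highest of the two numbers recorded; the step of a 25-fold higher number from compound 1 to compound 2 (1.40 log units; beyond the scatter) is the only measured step in the set.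

Compound 3 `COc1ccc2nccc(C3CN(C4CCN(Cc5ccc(Cl)c(Cl)c5)CC4)C(=O)O3)c2c1` is not yet measured. It differs from compound 2 by 3,4-dichlorophenyl in place of 4-cyanophenyl on a saturated chain carbon bound to an amine nitrogen in a ring. Going by the values given here, no measured pair here compares one aryl group with another on that carbon: the single step from compound 1 to compound 2 trades an alkyl chain for an aryl group and therefore gives no direct guide to the direction or size of an aryl-to-aryl swap. The expectation for compound 3 must thus be wide; its step of a 2.5-fold lower number from compound 2 to compound 3 (0.40 log units; beyond the scatter) is estimated only loosely. Compound 3 is expected to give 5000 nM in this assay, within a range from 1000 nM to 30000 nM.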

Compound 3, half-maximal inhibitory concentration: 126 nM
Compound 3: the middle estimate sits 40-fold (1.60 log units) above what was measured, outside the stated range (below it).
By their numbers in this assay, from the lowest: compound 3; then compound 1; then compound 2.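

In this assay, the earlier step could be read as a penalty for putting any aryl group on a saturated chain carbon bound to an amine nitrogen in a ring, but compound 3 rules out that reading. The change from 4-cyanophenyl to 3,4-dichlorophenyl gives a 100-fold lower number from compound 2 to compound 3 (2.00 log units; beyond the scatter), and the change from pentyl to 3,4-dichlorophenyl gives a 4.0-fold lower number from compound 1 to compound 3 (0.60 log units; beyond the scatter), which makes compound 3 the strongest inhibitor of the three and shows that this position responds strongly to what the aryl ring carries, not merely to whether an aryl group is present. No supporting data are available to explain why these two aryl groups behave so differently.

The compounds shown cannot separate the loss of the nitrile from the gain of the two chlorines, so it remains open whether a plain phenyl ring or a phenyl ring bearing a single chlorine would stay close to compound 3 or fall toward compound 2. Also open, as far as these compounds go, is how a trifluoromethyl-substituted phenyl ring, a cyclohexyl group or a longer chain at this position would compare with the pentyl group of compound 1 and the 3,4-dichlorophenyl group of compound 3.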